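A few compounds are considered here, and "the series" means these few. Any claim that something is new, unique, unknown or untested is made for them only; others in the source may bear on it.

Working notes, cytotoxicity series. Compound 2 `Cc1cc(/C=C/C#N)cc(C)c1Oc1ccnc(Nc2ccc(CN3CCN(S(=O)(=O)N(C)C)CC3)cc2)n1` gives 3070 nM in an ADME assay on MT4 cells (Homo sapiens) for cytotoxicity, read by MTT assay; a higher number here means that more compound is tolerated, a lower number that less compound is tolerated. Compound 1 `CCS(=O)(=O)N1CCN(Cc2ccc(Nc3nccc(Oc4c(C)cc(/C=C/C#N)cc4C)n3)cc2)CC1` gives 4600 nM in this assay, and compound 3 `CCS(=O)(=O)N1CCN(Cc2ccc(Nc3nccc(Oc4c(C)cc(C#N)cc4C)n3)cc2)CC1` gives 5240 nM in this assay. Compound 2 holds the lowest of the three numbers, with compound 1 nearest and compound 3 furthest, but both gaps are within the scatter, so the three compounds stand together and no order among them can be read.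

The next step leads to compound 4 `Cc1cc(/C=C/C#N)cc(C)c1Oc1ccnc(Nc2ccc(CN3CCCN(S(C)(=O)=O)CC3)cc2)n1`, the change being (4-(methylsulfonyl)-1,4-diazepan-1-yl in place of 4-(dimethylsulfamoyl)piperazin-1-yl on a saturated chain carbon bound to an aromatic carbon). Of the measured steps, the one that bears most on it is a 1.5-fold lower number from compound 1 to compound 2 (0.18 log units; within the scatter), since it also alters the substituent on the sulfonyl sulfur. The other measured step, a 1.1-fold higher number from compound 1 to compound 3 (0.06 log units; within the scatter), alters a different part of the shared core and mainly shows how little this assay moves across the set. Going by the values given here, neither measured step changed the ring that carries the sulfonyl group, and no measured compound holds a seven-membered ring, so that part of the change is untested. Given that the two measured steps in this assay stayed within the scatter, compound 4 is expected to stay with the set, with an expected step of a 1.1-fold higher number from compound 2 to compound 4 (0.06 log units; within the scatter) and no direction beyond the scatter. Compound 4 is therefore estimated at 3500 nM, with a range from 1700 nM to 7200 nM.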

Compound 4, half-maximal cytotoxic concentration: 17400 nM
Estimate against measurement, compound 4: 5.0-fold (0.70 log units) below; measured number outside the range, above it.
By their numbers in this assay, from the lowest: compounds 2, 1 and 3 (each within the scatter of the next); then compound 4.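

Going by these compounds alone, this position on the saturated chain carbon bound to an aromatic carbon is the first place where this assay responds beyond the scatter, with a 5.7-fold higher number from compound 2 to compound 4 (0.75 log units; beyond the scatter) and a 3.8-fold higher number from compound 1 to compound 4 (0.58 log units; beyond the scatter) for the same incoming group, 4-(methylsulfonyl)-1,4-diazepan-1-yl. The earlier change on the sulfonyl sulfur gave only a 1.5-fold lower number from compound 1 to compound 2 (0.18 log units; within the scatter) and stayed within the scatter, so exchanging ethyl for dimethylamino on the six-membered ring left the number in place, while replacing the whole group did not. Both new steps change the ring and the substituent on the sulfonyl sulfur together, so the shift belongs to the group as a whole and cannot be assigned to either part.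

Still open, from the compounds shown here alone, is which part carries the shift, and 4-(methylsulfonyl)piperazin-1-yl and 4-(ethylsulfonyl)-1,4-diazepan-1-yl would separate ring size from the sulfonyl substituent. Also open, going by these compounds, is whether the 4-(methylsulfonyl)-1,4-diazepan-1-yl group gives a similar step when cyano stands in place of 2-cyanoethenyl on the shared core. No supporting data are at hand to account for the shift.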